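The source may hold more compounds than are shown below. What is called first, only, known or untested is meant among the compounds shown, and "the series" means these compounds.

Of the compounds shown here, two have been measured in a functional assay on MCF7 cells (Homo sapiens) for antiproliferative activity, read by sulforhodamine B assay, with a stated time of 48 h; on this read-out lower numbers stand for stronger inhibition and higher numbers for weaker inhibition. Compound 1 `CC(C)C(=O)Nc1ccc(S(=O)(=O)Oc2ccccc2C(C)C)cc1` gives 8600 nM in this assay. Compound 2 `CC(C)C(=O)Nc1ccc(S(=O)(=O)Oc2ccccc2I)cc1` gives 8100 nM in this assay. Within the data shown here, the single measured step, a 1.1-fold lower number from compound 1 to compound 2 (0.03 log units; within the scatter), is an exchange on an aromatic carbon. Compound 2 stands at the lower of the two numbers, but its gap to compound 1 lies within the scatter, so the two compounds are not separated on this read-out.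

Compound 3 `O=C(CCCCl)Nc1ccc(S(=O)(=O)Oc2ccccc2I)cc1` has not yet been measured in this assay. It differs from compound 2 by 3-chloropropyl in place of isopropyl on a carbonyl carbon. Among the measured compounds shown here, no measured step touches the carbonyl carbon whose other neighbour is the amide-type nitrogen; the step from compound 1 to compound 2 alters a different part of the molecule and is itself within the scatter, so it gives no direction for this change. The measured pairs contain nothing that would point to a shift. The step of a 1.0-fold lower number from compound 2 to compound 3 (0.01 log units; within the scatter) is therefore expected to stay within the scatter. The estimate for compound 3 is 8000 nM, with a range from 3000 nM to 20000 nM.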

Compound 3, half-maximal inhibitory concentration: 6300 nM
Compound 3: middle estimate off by 1.3-fold (0.10 log units), on the high side; measured number inside the range.
By their numbers in this assay, from the lowest: compounds 3, 2 and 1 (each within the scatter of the next).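

In this assay, among these compounds, the exchange of isopropyl for 3-chloropropyl on the carbonyl carbon whose other neighbour is the amide-type nitrogen gives a 1.3-fold lower number from compound 2 to compound 3 (0.11 log units; within the scatter) and is the first reading at this position, which the earlier pair did not touch. With the iodo group held constant, this position takes a chlorine-bearing chain in place of a branched isopropyl group without a step beyond the scatter, so compound 2 and compound 3 are not separated on this read-out. No measurement available here bears on the reason for this outcome.

A plain propyl group on the same carbonyl carbon would show whether the chlorine contributes anything apart from the chain, while an amine, a carboxylic acid or a longer chain would test how far the tolerance seen for this single exchange extends. It also remains open whether 3-chloropropyl on the carbonyl carbon behaves the same way with isopropyl in place of iodo on the aromatic carbon, a combination absent from the compounds shown.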